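A larger amide group replaces the morpholine in compound 4

A few compounds are considered here, and "the series" means these few. Any claim that something is new, unique, unknown or untested is made for them only; others in the source may bear on it.

Of the compounds shown here, three sharing one core have so far been tested in an ADME assay on HepG2 cells (Homo sapiens) for inhibition, with a stated time of 48 h; a higher number here means that more compound is needed for the effect, a lower number that less compound is needed. Compound 1, `CC(C(=O)N1CCCCC1)N1CCN(S(=O)(=O)c2ccc(C(C)(C)C)cc2)CC1`, reached only a limit, > 40000 nM. Compound 2, `CC1CCN(C(=O)C(C)N2CCN(S(=O)(=O)c3ccc(C(C)(C)C)cc3)CC2)CC1`, also gave only a limit, > 40000 nM. Compound 3, `CC(C(=O)N1CCOCC1)N1CCN(S(=O)(=O)c2ccc(C(C)(C)C)cc2)CC1`, likewise stands at a limit, > 40000 nM, so no number is known for it. The steps between them, a step that the two limits leave unreadable from compound 1 to compound 2, a step that the two limits leave unreadable from compound 1 to compound 3 and a step that the two limits leave unreadable from compound 2 to compound 3, cannot be sized, since all three values sit at the limit of > 40000 nM in this assay, at which 3 of the 3 values shown sit.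

Compound 4, `CC(C(=O)N1CCCc2ccccc21)N1CCN(S(=O)(=O)c2ccc(C(C)(C)C)cc2)CC1`, differs from compound 3 by 1,2,3,4-tetrahydroquinolin-1-yl in place of morpholin-4-yl on a carbonyl carbon. The change is larger than the ones measured so far: a ring with one aromatic ring fused to it enters where a small saturated ring with two hetero atoms left. For the measured compounds named here, none of the measured steps reads as a number, so they give no direction for this change. The expected step from compound 3 to compound 4 in this assay is therefore a step that the limit leaves unreadable from compound 3 to compound 4, meaning that compound 4 is expected to sit near the limit again, at 45000 nM, with a range from 8000 nM to 200000 nM.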

Compound 4, half-maximal effective concentration: > 40000 nM
Compound 4 was reported as a limit; the forecaster's own chance of this, stated with the estimate: 70%; the middle value does not contradict the limit.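

Compound 4 joins compound 1, compound 2 and compound 3 at a limit rather than a number, so its steps to all three cannot be read: the limit of > 40000 nM in this assay, at which 4 of the 4 values shown sit.

The compounds shown leave open how much of each is needed for the effect in this assay, and whether changing the amide group alters that at all.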